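A few compounds are considered here, and "the series" means these few. Any claim that something is new, unique, unknown or untested is made for them only; others in the source may bear on it.

Of the compounds shown here, three have been measured in a functional assay on the whole organism (B cells) with Mus musculus as the target (a higher number here means a larger maximal response, a lower number a smaller maximal response), and one more awaits its number. Compound 1 `CC1OC(n2c(=O)n(C)c3c(O)nc(N)nc32)[C@H](O)[C@@H]1O` gives 0% in this assay. Compound 2 `[N-]=[N+]=NCC(O)Cn1c(=O)n(C2OC(CO)[C@@H](O)[C@H]2O)c2nc(N)nc(O)c21` gives 91% in this assay. Compound 3 `Cn1c(=O)n2c3c1c(=O)nc(N)n3CC1OC2[C@H](O)[C@@H]1O` gives 9% in this assay. Of the three, compound 2 stands highest: its nearest neighbour is compound 3, whose number lies lower by more than the scatter, and the furthest is compound 1, whose number lies lower still, also beyond the scatter. Within the data shown here, no two of the measured compounds differ in only one place, so no single step between measured compounds is available to lean on.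

The unmeasured compound 4 `CCOC(=O)Cn1c(=O)n(C2OC(CO)[C@@H](O)[C@H]2O)c2nc(N)nc(O)c21` is reached from compound 2 by one change, (ethoxycarbonyl in place of 2-azido-1-hydroxyethyl on a saturated chain carbon bound to an aromatic nitrogen). The 2-azido-1-hydroxyethyl group is the part of compound 2 that the other two measured compounds lack, and compound 2 is the only one of the three that reaches a large maximal response in this assay. On this basis a fall in this assay is expected for compound 4 on going a number 41 percentage points lower from compound 2 to compound 4 (beyond the scatter), though with wide uncertainty, since nothing measured shows the ethoxycarbonyl group on this chain. Compound 4 is therefore estimated at 50% in this assay, within a range of 10% to 90%.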

Compound 4, largest response reached (reported as maximal response), in percent of the reference or control that the assay uses: 86%
Estimate against measurement, compound 4: 36 percentage points below, within the range that was stated.
By their numbers in this assay, from the lowest: compounds 1 and 3 (each within the scatter of the next); then compounds 4 and 2 (each within the scatter of the next).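

In this assay, putting ethoxycarbonyl in place of 2-azido-1-hydroxyethyl on a saturated chain carbon bound to an aromatic nitrogen gives a number 5 percentage points lower from compound 2 to compound 4 (within the scatter). Among these compounds, this is the first direct reading at this position, and it shows that, for this pair, neither the azido group nor the chain hydroxyl is required for the large maximal response, since two differently built substituents, 3-azido-2-hydroxypropyl and (ethoxycarbonyl)methyl when cut one bond further out, cannot be told apart in this read-out. Nothing available explains why the two substituents read alike.

The compounds shown leave open whether the response at this position needs a carbonyl-bearing or otherwise substantial substituent at all, or whether a plain methyl group or the unsubstituted ring nitrogen would serve equally. They also leave open how far the position tolerates further change, for instance a carboxylic acid in place of the ethyl ester, a primary amide, or a longer chain carrying an amine.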